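Aryl exchange on the amino nitrogen: compound 2 to compound 3

The source may hold more compounds than are shown below. What is called first, only, known or untested is meant among the compounds shown, and "the series" means these compounds.

In a functional assay on U-937 cells (Homo sapiens) for antiproliferative activity, read by CCK-8 assay, with a stated time of 72 h (a lower number here means a stronger inhibitor, a higher number a weaker inhibitor), compound 1 (`Cc1cc(Nc2cc(N3CCN(C)CC3)nc(Nc3ccc(S(N)(=O)=O)cc3)n2)n[nH]1`) gives 100 nM and compound 2 (`COc1cccc(Nc2nc(Nc3cc(C)[nH]n3)cc(N3CCN(C)CC3)n2)c1`) gives 126 nM. These two values lie within the scatter of each other, so compound 2 stands level with compound 1 in this small set.

Compound 3 (`Cc1cc(Nc2cc(N3CCN(C)CC3)nc(Nc3ccc(C#N)cc3)n2)n[nH]1`) carries 4-cyanophenyl in place of 3-methoxyphenyl on a nitrogen on an aromatic ring.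

For the measured compounds named here, one measured step bears on this change, as it alters the same place: a 1.3-fold higher number from compound 1 to compound 2 (0.10 log units; within the scatter). That exchange of 4-sulfamoylphenyl for 3-methoxyphenyl stayed within the scatter. A single step is thin evidence, so the range is kept wide, and no shift beyond the scatter is expected. The expected step is a 1.1-fold lower number from compound 2 to compound 3 (0.06 log units; within the scatter). In this assay the estimate for compound 3 is 110 nM, with an expected range of 40 nM to 300 nM.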

Compound 3, half-maximal inhibitory concentration: 9.03 nM
Compound 3: middle estimate off by 12-fold (1.09 log units), on the high side; the whole stated range lies above it.
By their numbers in this assay, from the lowest: compound 3; then compounds 1 and 2 (each within the scatter of the next).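

In this assay the aryl group on this nitrogen proves able to move the number strongly, which the earlier exchange of a 1.3-fold higher number from compound 1 to compound 2 (0.10 log units; within the scatter) did not reveal. The 4-cyanophenyl group gives a 14-fold lower number from compound 2 to compound 3 (1.14 log units; beyond the scatter) against 3-methoxyphenyl, and cyano in place of sulfamoyl on an aromatic carbon gives an 11-fold lower number from compound 1 to compound 3 (1.04 log units; beyond the scatter) against the 4-sulfamoylphenyl compound, so compound 3 stands apart while compounds 1 and 2 remain level. Nothing in the data at hand offers an explanation for this step.

Open, on these data alone, is whether the step belongs to the nitrile at this ring position, as 3-cyanophenyl, 4-aminophenyl or 4-carboxyphenyl on the same nitrogen would test. Also open, as far as these compounds go, is whether it holds when another part of the shared core changes, since these three compounds differ only in this aryl group.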